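The source may report more compounds than this note shows. Statements on the series, on what has been measured and on what is new or still open speak of the compounds shown alone.

Measured compounds in an assay on HEK293 cells for positive allosteric modulation of metabotropic glutamate receptor 5 (Homo sapiens), read by FLIPR; on this read-out lower numbers stand for an effect already at smaller amounts and higher numbers for an effect only at larger amounts of compound:
- compound 1 `O=C(c1ccc(F)cc1)N1CC(c2nc(-c3cccc(F)c3)no2)C1`, giving 2400 nM
- compound 2 `O=C(c1ccc(F)cc1)N1CC(c2nc(-c3cccc(Cl)c3)no2)C1`, for which the assay reports only a limit, > 10000 nM
- compound 3 `CC1CCN(C(=O)N2CC(c3nc(-c4cccc(Cl)c4)no3)C2)C1`, for which the assay again reports only a limit, > 10000 nM

Going by the values given here, compound 1 is the only member of the set with a real number; the other two values sit at the limit of > 10000 nM in this assay, at which 2 of the 3 values shown sit. Among the compounds with values here, the one readable step, an at least 4.1-fold higher number from compound 1 to compound 2 (0.61 log units; beyond the scatter), comes from a chloro in place of fluoro on an aromatic carbon. The step that the two limits leave unreadable from compound 2 to compound 3 changes the group on the carbonyl carbon, but both of its values are limits, so its size cannot be read.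

Compound 4 `O=C([C@@H]1CC2CCC1C2)N1CC(c2nc(-c3cccc(F)c3)no2)C1` differs from compound 1 by a group of 7 heavy atoms (7 carbon; 2 five-membered non-aromatic rings of carbon only) in place of a group of 7 heavy atoms (6 carbon, 1 fluorine; one six-membered aromatic ring of carbon only), on a carbonyl carbon. This is a change at the carbonyl carbon, the same position touched in the step from compound 2 to compound 3, and that step gave no readable size. Within the data shown here, no measured step in this set therefore says whether a saturated bicyclic group at this position helps or harms. The expected step from compound 1 to compound 4, a 1.5-fold higher number from compound 1 to compound 4 (0.16 log units; within the scatter), is estimated with little confidence, and the estimate is drawn wide. For compound 4 the expected value in this assay is 3500 nM, within a range from 800 nM to 15000 nM.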

Compound 4, half-maximal effective concentration: 100 nM
The estimate for compound 4 lay 35-fold (1.54 log units) above the measured number, and the stated range ends above it.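

In this assay, a change at the carbonyl carbon now has a readable size: putting the saturated bicyclic group of 7 carbon atoms in place of 4-fluorophenyl gives a 24-fold lower number from compound 1 to compound 4 (1.38 log units; beyond the scatter), a large step well beyond the usual scatter. The two groups match in heavy-atom count, and neither carries a hydrogen-bond donor, acceptor or net charge, yet the aromatic ring of 4-fluorophenyl proves unnecessary for activity in this pair, as two non-aromatic rings of carbon only take its place and the number falls. Before this, the only other change at this carbonyl carbon, from compound 2 to compound 3, could not be read, as both of its values are limits: the limit of > 10000 nM in this assay, at which 2 of the 4 values shown sit.

As far as these compounds go, it remains open whether the same swap works with chloro in place of fluoro on the aromatic carbon, as in compound 2, and how other groups on the carbonyl carbon, such as cyclohexyl, tert-butyl or the mirror-image form of the bicyclic group, would compare. Nothing among the data shown explains why this single swap moves the number so far.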